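Bromo added to the thiourea phenyl of a weak antiproliferative

This account rests on a few compounds, and the source may have more. Where it says the series, first, only, none or still open, it means among the compounds named here.

Measured compounds: compound 1 `NC(=O)c1c(NC(=O)c2ccccc2Cl)sc2c1CCN(Cc1ccc(Cl)cc1Cl)C2`, 21100 nM; compound 2 `NC(=O)c1c(NC(=O)c2ccccc2Cl)sc2c1CCN(C(=S)Nc1ccccc1)C2`, 46700 nM.

Among the compounds with values here, in a functional assay on HeLa cells (Homo sapiens) for antiproliferative activity, with a stated time of 24 h (on this read-out higher numbers stand for weaker inhibition and lower numbers for stronger inhibition), compound 2 gives 46700 nM, the higher of the two numbers; the one change measured, a 2.2-fold higher number from compound 1 to compound 2 (0.35 log units; beyond the scatter), replaced the whole group on the ring amine. Compound 3 `NC(=O)c1c(NC(=O)c2ccccc2Cl)sc2c1CCN(C(=S)Nc1ccccc1Br)C2` differs from compound 2 by bromo in place of hydrogen on an aromatic carbon, placed ortho to a large group. Within the data shown here, no measured step bears on this change, so no shift beyond the scatter is expected, with a 1.2-fold lower number from compound 2 to compound 3 (0.09 log units; within the scatter). Compound 3 is estimated at 38000 nM, within 12000 nM to 100000 nM.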

Compound 3, half-maximal inhibitory concentration: 24600 nM
Estimate against measurement, compound 3: 1.5-fold (0.19 log units) above; the range from low to high includes it.
By their numbers in this assay, from the lowest: compounds 1, 3 and 2 (each within the scatter of the next, the first and the last beyond it).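

In this assay, bromo on the aromatic carbon ortho to a large group gives a 1.9-fold lower number from compound 2 to compound 3 (0.28 log units; within the scatter), so this position takes a bromine atom without a shift that can be told from the scatter. Exchanging the whole group on the ring amine now gives a 1.2-fold higher number from compound 1 to compound 3 (0.07 log units; within the scatter), so the 2-bromophenyl compound, unlike the phenyl compound, cannot be told apart from compound 1. No measurement shown here accounts for this result. The compounds shown leave open whether fluoro, methoxy or an amine on this carbon would move the number beyond the scatter, and whether bromo on another carbon of this ring would do so.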